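The compounds below may be only part of what the source reports. "The series", "measured", "known", "first", "only" and "open" are said of these compounds alone.

Measured so far: compound 1 `COc1cc2nc(/C=C/c3ccccc3)nc(N3CCC(CCNS(N)(=O)=O)CC3)c2cc1OC` gives 33% in an assay on cells for inhibition of Ectonucleotide pyrophosphatase/phosphodiesterase family member 1 (Homo sapiens), with a stated time of 60 min, tested at 1 uM; on this read-out lower numbers stand for less inhibition and higher numbers for more inhibition at the one concentration tested (going by the name of the read-out); compound 2 `COc1cc2nc(/C=C/c3ccncc3)nc(N3CCC(CCNS(N)(=O)=O)CC3)c2cc1OC` gives 79%.

For the measured compounds named here, compound 2 stands highest of the two numbers, with compound 1 its only neighbour, and the single measured step is a number 46 percentage points higher from compound 1 to compound 2 (beyond the scatter). Compound 3 `COc1cccc(/C=C/c2nc(N3CCC(CCNS(N)(=O)=O)CC3)c3cc(OC)c(OC)cc3n2)c1` differs from compound 2 in one place: 3-methoxyphenyl in place of pyridin-4-yl on a double-bonded chain carbon bound to a double-bonded chain carbon. Because the pyridin-4-yl that leaves is the very group whose entry gave a number 46 percentage points higher from compound 1 to compound 2 (beyond the scatter), and a carbon-only ring enters again, a fall beyond the scatter is expected; yet 3-methoxyphenyl is not the phenyl of compound 1, so the full reversal is uncertain. For compound 3 the expected step is a number 37 percentage points lower from compound 2 to compound 3 (beyond the scatter), giving an estimate of 42% within 20% to 65%.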

Compound 3, a percentage reported as inhibition, at one concentration (the size of the read-out at that concentration, not a potency): 88%
Compound 3: the middle estimate sits 46 percentage points below what was measured, outside the stated range (above it).
By their numbers in this assay, from the lowest: compound 1; then compounds 2 and 3 (each within the scatter of the next).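

In this assay, 3-methoxyphenyl in place of pyridin-4-yl gives a close result (a number 9 percentage points higher from compound 2 to compound 3 (within the scatter)), so at this position the ring nitrogen of pyridin-4-yl is not required for a high number. Methoxy in place of hydrogen on the carbon-only ring also matters (a number 55 percentage points higher from compound 1 to compound 3 (beyond the scatter)), so this single change separates compound 1 from compound 3 beyond the scatter. Nothing available explains either result.

Still open, from the compounds shown here alone, is how an ethoxy group or an amine would read in place of that methoxy. Also open, going by these compounds, is whether methoxy added to the pyridin-4-yl ring would change the number.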